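Pyridyl-boronic acid swap on a pyrimidine core

The source may hold more compounds than are shown below. What is called first, only, known or untested is meant among the compounds shown, and "the series" means these compounds.

Compound 1 `CN(Cc1ccc(B(O)O)cc1)c1ccc(C(=O)Nc2ccc(F)cc2)cn1` gives 1400 nM in a functional assay on RBL cells for antagonist activity at C-X-C chemokine receptor type 1 (Homo sapiens), read by fluorescence and calcium flux, with a stated time of 30 min; a higher number here means a weaker inhibitor, a lower number a stronger inhibitor. Compound 2 `CN(Cc1ccc(B(O)O)cc1)c1ncc(C(=O)Nc2ccc(F)cc2)cn1` has a core that differs from that of compound 1 in a way that is not broken down here. In this assay, among the measured compounds shown here, compound 2 gives 681 nM, the lowest of the three numbers so far. Compound 3 `CN(Cc1ccc(B(O)O)cn1)c1ccc(C(=O)Nc2ccc(F)cc2)cn1` gives 1700 nM. The change from compound 1 to compound 3 is a group of 9 heavy atoms (5 carbon, 1 boron, 1 nitrogen, 2 oxygen; one six-membered aromatic ring with 1 hetero atom) in place of a group of 9 heavy atoms (6 carbon, 1 boron, 2 oxygen; one six-membered aromatic ring of carbon only), on a saturated chain carbon bound to a nitrogen on an aromatic ring; the step was a 1.2-fold higher number from compound 1 to compound 3 (0.08 log units; within the scatter).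

Compound 4 `CN(Cc1ccc(B(O)O)cn1)c1ncc(C(=O)Nc2ccc(F)cc2)cn1` has not yet been measured. It carries the same kind of change, here on the core of compound 2: a group of 9 heavy atoms (5 carbon, 1 boron, 1 nitrogen, 2 oxygen; one six-membered aromatic ring with 1 hetero atom) in place of a group of 9 heavy atoms (6 carbon, 1 boron, 2 oxygen; one six-membered aromatic ring of carbon only), on a saturated chain carbon bound to a nitrogen on an aromatic ring. The two places read the same word for word, the change sitting on a saturated chain carbon bound to a nitrogen on an aromatic ring in both cases.

For the measured compounds named here, because the one measured instance of this change gave a 1.2-fold higher number from compound 1 to compound 3 (0.08 log units; within the scatter), the step from compound 2 to compound 4 is expected to be small, about a 1.2-fold higher number from compound 2 to compound 4 (0.08 log units; within the scatter). On that basis compound 4 is estimated at 820 nM in this assay, most likely between 400 nM and 1700 nM.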

Compound 4, half-maximal inhibitory concentration: 1700 nM
Compound 4: the middle estimate sits 2.1-fold (0.32 log units) below what was measured, within the range that was stated.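

In this assay the same change, a six-membered aromatic ring with 1 hetero atom in place of one of carbon only, gave a 2.5-fold higher number from compound 2 to compound 4 (0.40 log units; beyond the scatter) on the core of compound 2. Among the compounds shown here, although only this second step lies beyond the scatter, the two steps cannot be told apart: the same change on two cores in this assay, a 1.2-fold higher number (0.08 log units; within the scatter) from compound 1 to compound 3 and a 2.5-fold higher number (0.40 log units; beyond the scatter) from compound 2 to compound 4, 2.1-fold (0.31 log units) apart, within the scatter of two such steps. This gives no sign that the core alters the outcome of the change, but two pairs of compounds are too few to show that the change carries over unaltered from one core to another.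

The compounds shown leave open how the same change would read on any further core, and whether the result would hold if a carboxylic acid or a nitrile stood in place of the boronic acid. They also leave open what an amine or a longer chain on the shared core would do to the numbers in this assay.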